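Replacing 3-methoxyphenyl with 2,3-dichlorophenyl in the series

A few compounds are considered here, and "the series" means these few. Any claim that something is new, unique, unknown or untested is made for them only; others in the source may bear on it.

Three compounds sharing one core have numbers in an ADME assay on NHDF cells (Homo sapiens) for cytotoxicity, read by MTT assay, with a stated time of 72 h; a higher number here means a weaker inhibitor, a lower number a stronger inhibitor. Compound 1 (`COc1cccc(/C=C2\CCC/C(=C\c3ccccc3Cl)C2=O)c1OC`), carrying 2-chlorophenyl, gives 44200 nM. Compound 2 (`COc1cccc(/C=C2\CCC/C(=C\c3ccc(Br)cc3)C2=O)c1OC`), carrying 4-bromophenyl, gives 21400 nM. Compound 3 (`COc1cccc(/C=C2\CCC/C(=C\c3cccc(OC)c3OC)C2=O)c1`), carrying 3-methoxyphenyl, gives 16400 nM.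

Compound 3 stands at the low end of these numbers, together with compound 2: a 1.3-fold lower number from compound 2 to compound 3 (0.12 log units; within the scatter) lies within the scatter, whereas a 2.7-fold lower number from compound 1 to compound 3 (0.43 log units; beyond the scatter) lies beyond it but is modest. The step of a 2.1-fold lower number from compound 1 to compound 2 (0.32 log units; beyond the scatter) is also modest, so the two halogen-bearing compounds do not behave alike.

Compound 4 (`COc1cccc(/C=C2\CCC/C(=C\c3cccc(Cl)c3Cl)C2=O)c1OC`) differs from compound 3 in one place: 2,3-dichlorophenyl in place of 3-methoxyphenyl on a double-bonded chain carbon bound to a double-bonded ring carbon. In words, 2,3-dichlorophenyl stands in place of 3-methoxyphenyl on a double-bonded chain carbon bound to a double-bonded ring carbon.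

The closest guide is compound 1, the other chlorine-bearing member, with a 2.7-fold lower number from compound 1 to compound 3 (0.43 log units; beyond the scatter) read in reverse, which points towards a higher number. Compound 2 tempers this, with a 1.3-fold lower number from compound 2 to compound 3 (0.12 log units; within the scatter) showing that a halogen-bearing ring can sit level with compound 3. A small rise is therefore expected, and the estimated step is a 1.8-fold higher number from compound 3 to compound 4 (0.26 log units; within the scatter). In this assay the estimate for compound 4 is 30000 nM, with an expected range of 14000 nM to 60000 nM.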

Compound 4, half-maximal inhibitory concentration: > 50000 nM
Compound 4 ended at the assay's limit; the forecaster's own chance of this, stated with the estimate: 10%; middle value at least 1.6-fold (0.22 log units) away from the limit.
By their numbers in this assay, from the lowest: compounds 3 and 2 (each within the scatter of the next); then compound 1. At a limit, above all of these: compound 4.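

In this assay compound 4 ends at a limit of the assay and not at a number: the limit of > 50000 nM in this assay, at which 1 of the 4 values shown sits. Even so, the steps are informative at this position, on a double-bonded chain carbon bound to a double-bonded ring carbon: an at least 3.0-fold higher number from compound 3 to compound 4 (0.48 log units; beyond the scatter) and an at least 2.3-fold higher number from compound 2 to compound 4 (0.36 log units; beyond the scatter) both lie beyond the scatter, so a halogen-bearing ring here does not necessarily stay level with compound 3, as the 4-bromophenyl of compound 2 did. The added chloro is a different matter, since an at least 1.1-fold higher number from compound 1 to compound 4 (0.05 log units; that floor lies within the scatter) gives only a floor within the scatter, and the step from 2-chlorophenyl to 2,3-dichlorophenyl therefore has no established size.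

The compounds shown leave open where the true number of compound 4 lies past the limit, and with it whether the second chlorine changes anything relative to compound 1. On these data alone, how 3-chlorophenyl, or a phenyl ring carrying an amine or a carboxylic acid, would read at this place also stays open, so the chlorine pattern cannot yet be separated from the presence of chlorine alone.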